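The source may report more compounds than this note shows. Statements on the series, on what has been measured and on what is new or still open speak of the compounds shown alone.

Measured so far:
- compound 1, `CC(=O)O[C@H](CC/C(C)=C/CCc1ccc2c(c1)C(=O)C(C)=CC2=O)[C@@](C)(O)CCC=C(C)C`: 4700 nM
- compound 2, `CC(C)=CCC/C(=C/CC/C(C)=C/CC/C(C)=C/CC1=CC(=O)C(C)=CC1=O)CO`: > 48800 nM

Both compounds were tested in a functional assay on MDA-MB-231 cells (Homo sapiens) for cytotoxicity, read by MTT assay, with a stated time of 6 days; a lower number here means a stronger inhibitor, a higher number a weaker inhibitor. Compound 1 gives 4700 nM in this assay. Compound 2 reaches only the limit of the assay, > 48800 nM, so for compound 2 no number is known, only that it sits at the upper boundary of what the assay can report, as noted in the limit of > 48800 nM in this assay, at which 1 of the 2 values shown sits. Going by the values given here, of the two values shown, the one for compound 1 is a number and the one for compound 2 is a limit, and nothing more can be said of their pair, as they differ in several places at once.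

Compound 3, `CC(=O)OC/C(=C\CC/C(C)=C/CC/C(C)=C/CC1=CC(=O)C(C)=CC1=O)CCC=C(C)C`, has not yet been measured. It is built from compound 2 by one change: acetyl in place of hydrogen on an oxygen on a saturated carbon.

No comparable step between two measured compounds is shown, so the expected size of this change rests on nothing but the starting point. Starting from a limit, the step from compound 2 to compound 3 is estimated as an at least 1.3-fold lower number from compound 2 to compound 3 (0.14 log units; that floor lies within the scatter), with no direction claimed beyond the usual scatter. In this assay compound 3 is expected to give about 35000 nM, within a range of 8000 nM to 100000 nM.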

Compound 3, half-maximal inhibitory concentration: 33200 nM
Compound 3: the middle estimate sits 1.1-fold (0.02 log units) above what was measured; low and high end bracket the measured number.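

This is the only pair shown that differs in one place, and it gives the hydroxymethyl to acetoxymethyl change a reading: in this assay, compound 3 gives 33200 nM, a number and not a boundary. The change amounts to an at least 1.4-fold lower number from compound 2 to compound 3 (0.16 log units; that floor lies within the scatter), so what it offers is a floor, and no direction can be claimed from it beyond the usual scatter. The true size of the step stays unknown because compound 2 rests on a limit and not on a number: the limit of > 48800 nM in this assay, at which 1 of the 3 values shown sits.

Left open is how much the reading at this place depends on acetyl itself, as this single change says nothing about what an amine, a carboxylic acid or a longer chain on that oxygen or carbon would give. Also open, from the compounds shown here alone, is whether the hydroxy to acetoxy change would read the same way on the core of compound 1, which gives 4700 nM and differs from compound 3 in several places.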